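The source may hold more compounds than are shown below. What is called first, only, known or untested is meant among the compounds shown, and "the series" means these compounds.

Measured compounds in a functional assay on MCF7 cells (Homo sapiens) for antiproliferative activity, read by MTT assay, with a stated time of 48 h; a higher number here means a weaker inhibitor, a lower number a stronger inhibitor:
compound 1 `COc1ncc(-c2ccc3nc(NC(C)=O)nn3c2)cc1NS(=O)(=O)c1ccc(F)cc1`, 840 nM
compound 2 `COc1ncc(-c2ccc3nc(NC(C)=O)nn3c2)cc1NS(=O)(=O)c1ccc(Cl)cc1`, 2010 nM
compound 3 `COc1ncc(-c2ccc3nc(NC(C)=O)nn3c2)cc1NS(=O)(=O)c1ccc(F)cc1F`, 870 nM

Compound 1 holds the lowest number of the three; compound 3 sits within the scatter of it, while compound 2 lies beyond it, a 2.4-fold higher number from compound 1 to compound 2 (0.38 log units; beyond the scatter). The two other steps, a 1.0-fold higher number from compound 1 to compound 3 (0.02 log units; within the scatter) and a 2.3-fold lower number from compound 2 to compound 3 (0.36 log units; beyond the scatter), also concern only the aryl on the sulfonyl sulfur.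

Compound 4 `CNC(=O)CNc1nc2ccc(-c3cnc(OC)c(NS(=O)(=O)c4ccc(F)cc4)c3)cn2n1` differs from compound 1 elsewhere: (methylcarbamoyl)methyl in place of acetyl on a nitrogen on an aromatic ring. Among the measured compounds shown here, none of the measured steps touches this part of the shared core, so they give no direct read on the change. Without a comparable step in the series, no shift beyond the scatter is expected in this assay, and compound 4 is estimated at 900 nM, range 300 nM to 3000 nM, meaning an expected step of a 1.1-fold higher number from compound 1 to compound 4 (0.03 log units; within the scatter).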

Compound 4, half-maximal inhibitory concentration: 2540 nM
For compound 4 the middle estimate is 2.8-fold (0.45 log units) below the measured one; the range from low to high includes it.
By their numbers in this assay, from the lowest: compounds 1 and 3 (each within the scatter of the next); then compounds 2 and 4 (each within the scatter of the next).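

The nitrogen on the aromatic ring is not a silent position in this assay: (methylcarbamoyl)methyl in place of acetyl gives a 3.0-fold higher number from compound 1 to compound 4 (0.48 log units; beyond the scatter), so the number responds to changes outside the aryl on the sulfonyl sulfur. This single step cannot separate the loss of acetyl from the entry of the group's hydrogen-bond donor. No measurement at hand gives a reason for the shift.

Open, going by these compounds, is how a free amine, a propionyl or a carboxylic acid on this nitrogen would read. Also open, on these data alone, is whether the step holds with 2,4-difluorophenyl on the sulfonyl sulfur.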